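The compounds below may be only part of what the source reports. "The series", "measured", "known", "first", "only" and "open" are said of these compounds alone.

Compound 1 `O=C(c1cc(Br)cc(Br)c1)c1cc(Cl)ccc1OCCn1ccc(=O)[nH]c1=O` carries a 3,5-dibromophenyl group on a carbonyl carbon. In an ADME assay on MT4 cells (Homo sapiens) for cytotoxicity, read by MTT assay, with a stated time of 4 days (on this read-out higher numbers stand for lower toxicity in this test and lower numbers for higher toxicity in this test), compound 1 gives > 236000 nM as its reading, which is a limit of the assay and not a number. Compound 1 therefore stands at a limit, with no exact value to its name. Compound 2 `Cc1cc(C)cc(C(=O)c2cc(Br)ccc2OCCn2ccc(=O)[nH]c2=O)c1` gives > 282000 nM as its reading in this assay and that too is a limit. Among the measured compounds shown here, the two limits offer no measured step and cannot be ranked against each other.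

Compound 3 `Cc1cccc(C(=O)c2cc(Cl)ccc2OCCn2ccc(=O)[nH]c2=O)c1` has not yet been measured. It has 3-methylphenyl in place of 3,5-dibromophenyl on a carbonyl carbon, with 3-methylphenyl in place of 3,5-dibromophenyl on a carbonyl carbon as the counted difference from compound 1.

Neither measured compound has given a number, so the expectation rests on two limits alone. Compound 2 at > 282000 nM supports the expectation that this change brings no step beyond the scatter in this assay for compound 3. The expected shift is a step that the limit leaves unreadable from compound 1 to compound 3 and no more. For compound 3 the estimate is 300000 nM with an expected range from 120000 nM to 340000 nM and a good chance of another limit.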

Compound 3, half-maximal cytotoxic concentration: > 325000 nM
Compound 3 gave a limit, no number; the forecaster's own chance of this, stated with the estimate: 75%; middle value at least 1.0-fold (0.03 log units) away from the limit.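

In this assay compound 3 gives > 325000 nM, which is a limit of the assay and not a number. Among the compounds shown here, compound 1 also stands at a limit, so no step between compound 1 and compound 3 can be read. The compounds shown leave open whether 3-methylphenyl and 3,5-dibromophenyl on a carbonyl carbon differ at all on this read-out.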